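Three Limits and an Expected Fourth

The source may hold more compounds than are shown below. What is called first, only, known or untested is meant among the compounds shown, and "the series" means these compounds.

Compound 1 `CC(C)Nc1nc(N(C)C)c2ccccc2n1` gives <= 10000 nM in a physicochemical assay for solubility, at pH 7.4 (a lower number here means a less soluble compound, a higher number a more soluble compound), a value that is a limit of the assay.
Compound 2 `CCCCNc1nc(NCCCC)c2ccccc2n1` gives <= 10000 nM in this assay, also a limit.
Compound 3 `CNc1nc(NCc2ccccc2)nc2ccccc12` gives <= 10000 nM in this assay, again a limit.

Going by the values given here, compound 3 therefore stands where every value so far stands, as the limit of <= 10000 nM in this assay, at which 3 of the 3 values shown sit, records; nothing on these numbers sets it apart from compound 1 or compound 2. Compound 4 `CCCCNc1nc(NCc2ccccc2)nc2ccccc12` differs from compound 3 by propyl in place of hydrogen on a saturated chain carbon bound to a nitrogen on an aromatic ring. Among the compounds with values here, no two measured compounds differ in one place, so no measured step gives the size of this change. The step that the limit leaves unreadable from compound 3 to compound 4 is expected to be none beyond the scatter, with compound 4 most likely staying at the same limit in this assay. Compound 4 is estimated at 3000 nM, between 300 nM and 10000 nM.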

Compound 4, solubility: <= 10000 nM
Compound 4: only a limit was reported (the forecaster's own chance of this, stated with the estimate: 80%); the middle value lies beyond the limit too.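

Neither the step from compound 3 to compound 4 nor that from compound 2 to compound 4 can be read, since all these values are limits: the limit of <= 10000 nM in this assay, at which 4 of the 4 values shown sit.

The compounds shown leave open how large any one-place change would be in this assay.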